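Pyrrolidin-1-yl to 4-methylpiperidin-1-yl on compound 1

The source may report more compounds than this note shows. Statements on the series, on what has been measured and on what is new or still open speak of the compounds shown alone.

Measured so far in a functional assay on NCI-H460 cells (Homo sapiens) for cytotoxicity, read by MTT assay, with a stated time of 72 h; a higher number here means a weaker inhibitor, a lower number a stronger inhibitor:
compound 1 `COc1cc2c(Oc3ccc(NC(=O)c4cn(-c5ccccc5Cl)nn4)cc3F)ccnc2cc1OCCCN1CCCC1` gives 190 nM
compound 2 `COc1cc2c(Oc3ccc(NC(=O)c4cn(-c5ccccc5C)nn4)cc3F)ccnc2cc1OCCCN1CCCC1` gives 1260 nM
compound 3 `COc1cc2c(Oc3ccc(NC(=O)c4cn(-c5c(C)cccc5C)nn4)cc3F)ccnc2cc1OCCCN1CCCC1` gives 1560 nM

Compound 1 holds the lowest number of the three; a 6.6-fold higher number from compound 1 to compound 2 (0.82 log units; beyond the scatter) and an 8.2-fold higher number from compound 1 to compound 3 (0.91 log units; beyond the scatter) both lie beyond the scatter, so it is the most potent of the measured set, while a 1.2-fold higher number from compound 2 to compound 3 (0.09 log units; within the scatter) stays within the scatter. Compound 4 `COc1cc2c(Oc3ccc(NC(=O)c4cn(-c5ccccc5Cl)nn4)cc3F)ccnc2cc1OCCCN1CCC(C)CC1` differs from compound 1 only by 4-methylpiperidin-1-yl in place of pyrrolidin-1-yl on a saturated chain carbon, three bonds along the chain from an oxygen on an aromatic ring. Going by the values given here, none of the measured steps touches this end of the chain; all three vary the group on the aromatic nitrogen, so no measured step bears directly on the change. With nothing to suggest a shift, the expectation in this assay is for no step beyond the scatter, no change at the digits printed from compound 1 to compound 4 (within the scatter). Compound 4 is therefore estimated at 190 nM, within 80 nM to 450 nM.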

Compound 4, half-maximal inhibitory concentration: 230 nM
Compound 4: middle estimate off by 1.2-fold (0.08 log units), on the low side, within the range that was stated.
By their numbers in this assay, from the lowest: compounds 1 and 4 (each within the scatter of the next); then compounds 2 and 3 (each within the scatter of the next).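

Replacing pyrrolidin-1-yl with 4-methylpiperidin-1-yl on the saturated chain carbon leaves this assay within the scatter, at a 1.2-fold higher number from compound 1 to compound 4 (0.08 log units; within the scatter). Going by these compounds alone, the earlier compounds varied only the group on the aromatic nitrogen, so this is the only reading at this end of the chain, and here a six-membered ring carrying a methyl matches the five-membered ring. No available data explain this result.

Still open, from the compounds shown here alone, is whether a morpholine, a piperazine or an open-chain dimethylamino group at this position would stay within the scatter of compound 1. A shorter or longer chain linking the amine to the oxygen also remains untested in the compounds shown.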